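The source may report more compounds than this note shows. Statements on the series, on what has been measured and on what is new or still open speak of the compounds shown alone.

Compound 1 `COc1ccc(S(=O)(=O)Oc2ccccc2NC(=O)c2ccnc3ccccc23)cc1`: > 10000 nM (a limit)
Compound 2 `COc1ccc(S(=O)(=O)Oc2ccccc2NC(=O)c2ccco2)cc1`: 19 nM

Among the measured compounds shown here, in a functional assay on HCT-15 cells (Homo sapiens) for antiproliferative activity (on this read-out lower numbers stand for stronger inhibition and higher numbers for weaker inhibition), compound 2 gives 19 nM, the only true number so far. Compound 1 reads > 10000 nM, which is a limit of the assay and not a number.

Compound 3 `COc1ccc(S(=O)(=O)Oc2ccccc2NC(=O)Oc2ccccc2)cc1` keeps the core of compound 2 and alters one group on a carbonyl carbon: phenoxy in place of furan-2-yl on a carbonyl carbon. In short, phenoxy stands in place of furan-2-yl. For the measured compounds named here, only one measured step bears on this place, an at least 520-fold lower number from compound 1 to compound 2 (2.72 log units; beyond the scatter). That single large step shows that the group here can matter greatly, but it cannot tell how phenoxy will behave. A moderate move towards weaker inhibition in this assay is therefore expected, with wide uncertainty. The expected change is a 7.9-fold higher number from compound 2 to compound 3 (0.90 log units; beyond the scatter). For compound 3 the estimated value is 150 nM, with an expected range of 15 nM to 2500 nM.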

Compound 3, half-maximal inhibitory concentration: > 10000 nM
Compound 3: no number, only a limit; the forecaster's own chance of this, stated with the estimate: 10%; middle value at least 66-fold (1.82 log units) from the limit.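

Replacing furan-2-yl with phenoxy on this carbonyl carbon gives an at least 520-fold higher number from compound 2 to compound 3 (2.72 log units; beyond the scatter) in this assay, so the sharp loss of inhibition is no longer seen with quinolin-4-yl alone. Among the compounds shown here, two different groups have now failed to keep the inhibition of compound 2, and furan-2-yl is the only one of the three groups here with a true number. The step between compound 1 and compound 3 cannot be read, as both values are limits and not numbers: the limit of > 10000 nM in this assay, at which 2 of the 3 values shown sit.

On these data alone, what remains open is which part of the change from furan-2-yl to phenoxy matters, the ring or the oxygen that links phenoxy to the carbonyl carbon. A plain phenyl group would help separate the two, while thiophen-2-yl would show whether another five-membered aromatic ring can take the place of furan-2-yl.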